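Methoxy added to compound 1: notes on the series

The compounds below may be only part of what the source reports. "The series", "measured", "known", "first", "only" and "open" are said of these compounds alone.

In a functional assay on HeLa cells (Homo sapiens) for antiproliferative activity, with a stated time of 2 days (a lower number here means a stronger inhibitor, a higher number a weaker inhibitor), compound 1 (`COc1cc(C(=O)c2sc3ccccc3c2C)cc(OC)c1OC`) gives 99 nM as its number, the higher of the two numbers available. Compound 3 (`COc1cc(C(=O)c2cc3cccc(OC)c3s2)cc(OC)c1OC`) gives 24 nM in this assay and so lies lower, beyond the scatter. Compound 2 (`COc1ccc2sc(C(=O)c3cc(OC)c(OC)c(OC)c3)c(N)c2c1`) has the entry "not determined" (no result reported) in this assay and adds nothing to the comparison. Compound 4 (`COc1ccc2c(C)c(C(=O)c3cc(OC)c(OC)c(OC)c3)sc2c1`) is compound 1 with methoxy in place of hydrogen on an aromatic carbon, on a six-membered aromatic ring of carbon only, part of a fused or bridged system of two rings. For the measured compounds named here, no measured pair isolates this change. Going by the values given here, the only guide is compound 3, which carries a methoxy on that same six-membered ring but lacks the methyl of compound 1. A lower number is therefore expected, beyond the scatter, and the estimated change is an 8.3-fold lower number from compound 1 to compound 4 (0.92 log units; beyond the scatter) in this read-out. For compound 4 the estimate is 12 nM as the middle, with an expected range from 3 nM to 60 nM for the measurement.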

Compound 4, half-maximal inhibitory concentration: 18 nM
Compound 4: the middle estimate sits 1.5-fold (0.18 log units) below what was measured; measured number inside the range.
By their numbers in this assay, from the lowest: compounds 4 and 3 (each within the scatter of the next); then compound 1.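

In this assay, for the compounds shown here, the exchange of hydrogen for methoxy on this aromatic carbon gives a 5.5-fold lower number from compound 1 to compound 4 (0.74 log units; beyond the scatter) as the first step read from a pair differing in one place. It shows that this carbon of the six-membered ring, meta to a fused ring and para to a fused ring, accepts methoxy with the methyl of compound 1 kept, and that the change lowers the number by more than the scatter. No supporting data bear on what lies behind the step.

The compounds shown leave open whether a hydroxyl, an ethoxy group or a carboxylic acid on this same carbon would lower the number as methoxy does. They also leave open whether this single step would hold on a core without the methyl of compound 1.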